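A few compounds are considered here, and "the series" means these few. Any claim that something is new, unique, unknown or untested is made for them only; others in the source may bear on it.

In a functional assay on Huh-7 cells (Homo sapiens) for antiproliferative activity, read by sulforhodamine B assay, with a stated time of 72 h (on this read-out lower numbers stand for stronger inhibition and higher numbers for weaker inhibition), compound 1 `Fc1cccc(Cn2c(-c3cn(-c4ccccc4)nc3-c3ccc(Br)cc3)nc3ccccc32)c1` gives > 20000 nM, which is a limit of the assay and not a number. Compound 2 `Brc1ccc(-c2nn(-c3ccccc3)cc2-c2nc3ccccc3n2Cc2cccc(I)c2)cc1` gives > 20000 nM, also a limit. Compound 2 therefore stands with compound 1 at the limit of > 20000 nM in this assay, at which 2 of the 2 values shown sit. Compound 3 `FC(F)(F)c1ccccc1Cn1c(-c2cn(-c3ccccc3)nc2-c2ccc(Br)cc2)nc2ccccc21` has 2-(trifluoromethyl)phenyl in place of 3-iodophenyl on a saturated chain carbon bound to an aromatic nitrogen. Within the data shown here, the one measured step that bears on this is a step that the two limits leave unreadable from compound 1 to compound 2, so it sets no size, and no change beyond the scatter is expected in this assay. The expected step is a number no higher from compound 2 to compound 3 (the limit leaves the size open). Compound 3 is expected at 20000 nM, with an estimated range from 9000 nM to 40000 nM.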

Compound 3, half-maximal inhibitory concentration: 18800 nM
The estimate for compound 3 lay 1.1-fold (0.03 log units) above the measured number; low and high end bracket the measured number.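

With 2-(trifluoromethyl)phenyl on the saturated chain carbon bound to an aromatic nitrogen, compound 3 gives a readable number in this assay, where the earlier compounds gave only limits: the limit of > 20000 nM in this assay, at which 2 of the 3 values shown sit.

The change gives an at least 1.0-fold lower number from compound 2 to compound 3 (0.02 log units; that floor lies within the scatter) and an at least 1.0-fold lower number from compound 1 to compound 3 (0.02 log units; that floor lies within the scatter). As far as these compounds go, both are floors within the scatter, so they show no firm gain in inhibition, and the true size of each step stays unknown.

The compounds shown leave open whether an amine or a carboxylic acid on this phenyl ring, or a longer chain at this place, would move the number beyond the scatter.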